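The source may hold more compounds than are shown below. What is called first, only, known or untested is meant among the compounds shown, and "the series" means these compounds.

The measured compounds in a functional assay on HGC-27 cells (Homo sapiens) for inhibition, read by MTT assay, with a stated time of 72 h; on this read-out higher numbers stand for weaker inhibition and lower numbers for stronger inhibition:

Compound 1, `Cc1cc(N2CC[C@@H](C)[C@@H](N(C)c3ncnc4[nH]ccc34)C2)n2nc(SCc3ccccc3Br)nc2n1`, gives 21300 nM.
Compound 2, `CCCCCc1c(C)nc2nc(SCc3ccc(Cl)cc3)nn2c1N1CC[C@@H](C)[C@@H](N(C)c2ncnc3[nH]ccc23)C1`, gives only a limit of the assay, > 100000 nM.
Compound 3, `Cc1cc(N2CC[C@@H](C)[C@@H](N(C)c3ncnc4[nH]ccc34)C2)n2nc(SCc3ccc(F)c(Cl)c3)nc2n1`, likewise gives only a limit, > 100000 nM.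

Going by the values given here, compound 1 thus stands as the one compound with an actual number; the other two sit at a limit, the one described by the limit of > 100000 nM in this assay, at which 2 of the 3 values shown sit. The unmeasured compound 4, `Cc1cc(N2CC[C@@H](C)[C@@H](N(C)c3ncnc4[nH]ccc34)C2)n2nc(SCc3ccc([N+](=O)[O-])cc3)nc2n1`, differs from compound 1 in one place: 4-nitrophenyl in place of 2-bromophenyl on a saturated chain carbon bound to a sulfur. Among the compounds with values here, only one measured step changes that same place: an at least 4.6-fold higher number from compound 1 to compound 3 (0.67 log units; beyond the scatter), a weakening that ran into the limit. Within the data shown here, no measured compound carries a 4-nitrophenyl at that position, so the direction is read from that step alone and its size is uncertain. The expected step is a 3.8-fold higher number from compound 1 to compound 4 (0.57 log units; beyond the scatter). For compound 4 the estimate in this assay is 80000 nM, with a range from 25000 nM to 300000 nM, and a real chance that only a limit is reported.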

Compound 4, half-maximal inhibitory concentration: 29400 nM
Estimate against measurement, compound 4: 2.7-fold (0.43 log units) above; measured number inside the range.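

In this assay, 4-nitrophenyl in place of 2-bromophenyl on the saturated chain carbon bound to a sulfur gives a 1.4-fold higher number from compound 1 to compound 4 (0.14 log units; within the scatter), so the two compounds cannot be told apart. The earlier compounds shown here showed only a loss on replacing 2-bromophenyl, whereas an at least 3.4-fold lower number from compound 3 to compound 4 (0.53 log units; beyond the scatter) shows that this place does not lose activity with every replacement and that the outcome depends on which substituted phenyl is present. That second step is only a bound, as one of its ends is not a number: the limit of > 100000 nM in this assay, at which 2 of the 4 values shown sit.

All the groups compared here are substituted phenyls, and none gives a number clearly lower than that of compound 1. Going by these compounds, how an amine or a carboxylic acid on that phenyl ring, or a plain alkyl chain in its place, would read remains open.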